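One Atom Swapped: Sulfur to Selenium in Compound 1

A few compounds are considered here, and "the series" means these few. Any claim that something is new, unique, unknown or untested is made for them only; others in the source may bear on it.

Three compounds have been measured in a functional assay on MCF7 cells (Homo sapiens) for antiproliferative activity, read by MTT assay, with a stated time of 48 h; on this read-out higher numbers stand for weaker inhibition and lower numbers for stronger inhibition:
- compound 1 `COc1ccc2c(/C=C/C(=O)c3cc(OC)c(OC)c(SC)c3)c[nH]c2c1` gives 101 nM
- compound 2 `COc1cc(C(=O)/C=C/c2c[nH]c3ccccc23)cc(SC)c1OC` gives 186 nM
- compound 3 `COc1ccc2c(/C=C/C(=O)c3cc(OC)c(OC)c(SC)c3)cn(C)c2c1` gives 166 nM

Compound 1 has the lowest of the three numbers, but its distance to the others is small: a 1.8-fold higher number from compound 1 to compound 2 (0.27 log units; within the scatter), and a 1.6-fold higher number from compound 1 to compound 3 (0.22 log units; within the scatter). Both steps lie within the scatter, so on these data compound 1 cannot be called stronger than compound 2 or compound 3; the three simply look alike.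

Compound 4 `COc1ccc2c(/C=C/C(=O)c3cc(OC)c(OC)c([Se]C)c3)c[nH]c2c1` is the untested member. Compared with compound 1 the change is a group of 2 heavy atoms (1 carbon, 1 selenium; no ring) in place of a group of 2 heavy atoms (1 carbon, 1 sulfur; no ring), on an aromatic carbon. The methylsulfanyl group that leaves is kept unchanged in compound 2 and compound 3, so neither measured step speaks to what happens when it is replaced; the two steps that are known concern a methoxy group elsewhere on the core and a methyl on the aromatic nitrogen, and each of them stayed within the scatter. With nothing in the measured set touching this group, the most reasonable expectation is a number close to that of compound 1, with no step beyond the scatter in either direction: compound 4 is expected to sit at a 1.1-fold lower number from compound 1 to compound 4 (0.05 log units; within the scatter). The estimate for compound 4 is therefore 90 nM, with a plausible range from 40 nM to 220 nM.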

Compound 4, half-maximal inhibitory concentration: 83 nM
Compound 4: the middle estimate sits 1.1-fold (0.04 log units) above what was measured; low and high end bracket the measured number.
By their numbers in this assay, from the lowest: compounds 4, 1, 3 and 2 (each within the scatter of the next, the first and the last beyond it).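

Among these compounds, this is the first result in which the methylsulfanyl group itself is replaced: in this assay, selenium in place of sulfur on this aromatic carbon gives a 1.2-fold lower number from compound 1 to compound 4 (0.09 log units; within the scatter). At this position, ortho to a methoxy group, the exchange of one atom therefore leaves compound 4 indistinguishable from compound 1 on this read-out, even though the computed hydrogen-bond acceptor count differs between the leaving and entering groups. No supporting measurement is available that could explain this outcome or show how the two compounds might differ beyond this read-out.

The compounds shown leave open how much change this position can take, since both groups placed there have 2 heavy atoms and no ring; an amine, a hydroxyl group or a longer chain such as ethylsulfanyl could show whether it accepts a different kind of group or a larger one. They also leave open whether the selenium exchange would give a similar result in the settings of compound 2 and compound 3, where the methoxy group on the core is absent or the aromatic nitrogen carries a methyl.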